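A few compounds are considered here, and "the series" means these few. Any claim that something is new, unique, unknown or untested is made for them only; others in the source may bear on it.

Measured compounds so far:

compound 1, `CC(=O)SCCC(CCCCC(=O)Nc1ccccc1)SC(C)=O`: 23%
compound 2, `CC(=O)SCCC(CCCCC(=O)Nc1ccc(Cl)cc1)SC(C)=O`: 72%
compound 3, `O=C(CCCCC(CCSC(=O)c1ccccc1)SC(=O)c1ccccc1)Nc1ccccc1`: "not active" (no number reported)

Compound 1 and compound 2 share one core. In a functional assay on KB cells (Homo sapiens) for inhibition, read by MTT assay, with a stated time of 24 h, tested at 100 ug/mL (a higher number here means more inhibition of growth at the concentration tested, a lower number less inhibition of growth), compound 1 gives 23% and compound 2 gives 72%. The difference between the two is chloro in place of hydrogen on an aromatic carbon. Within the data shown here, the step of a number 49 percentage points higher from compound 1 to compound 2 (beyond the scatter) is the only measured step in the set.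

Compound 3 rests on a second core, which carries the same anilide end as compound 1. How the two cores differ is not broken down here. In this assay compound 3 is recorded as "not active" (no number reported), with no number given.

Compound 4, `O=C(CCCCC(CCSC(=O)c1ccccc1)SC(=O)c1ccccc1)Nc1ccccc1Cl`, is not yet measured. It differs from compound 3 by chloro in place of hydrogen on an aromatic carbon. Among the measured compounds shown here, this is the same kind of change as the one from compound 1 to compound 2, but the place is not the same: in compound 2 the chloro sits para to a large group, in compound 4 it sits ortho to a large group, and the core underneath is the second one.

For compound 4 in this assay a step of the size seen from compound 1 to compound 2 is not expected, since the change stands on a different core and at a different place, and since compound 3 gives "not active" (no number reported). Compound 4 is estimated at 25%, with the expected range from 0% to 60%.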

Compound 4, percent growth inhibition at one concentration: "not active" (no number reported)
Nothing numeric was reported for compound 4, and the estimate cannot be compared.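

In this assay, among these compounds, compound 3 gives "not active" (no number reported) and compound 4 gives "not active" (no number reported) without a number on either side, and no step between the two can be read. Open remains whether chloro in place of hydrogen has any effect on the core of compound 3, and how that core compares with the core of compound 1. Nothing available bears on this result.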